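Compound 3 to compound 4: hydrogen in place of fluoro

The source may report more compounds than this note shows. Statements on the series, on what has been measured and on what is new or still open speak of the compounds shown alone.

In an ADME assay on the whole organism for pharmacokinetics, with Mus musculus as the target, at a dose of 10 mg/kg by the oral route (on this read-out lower numbers stand for lower exposure and higher numbers for higher exposure at the dose given), compound 1 `CC1=C(c2ccc(S(C)(=O)=O)cc2)C(c2ccc(OC[C@H](C)N3CC[C@@H](C)C3)cc2)Oc2ccc(O)cc21` gives "not determined" (no result reported). Of the two numbers available, the higher belongs to compound 3 `CC1=C(c2ccc(F)cc2)C(c2ccc(OC[C@H](C)N3CC[C@@H](C)C3)cc2)Oc2ccc(O)cc21` at 2000 ng.h/mL, and the lower to compound 2 `CC1=C(c2cccc(O)c2)C(c2ccc(OC[C@H](C)N3CC[C@@H](C)C3)cc2)Oc2ccc(O)cc21` at 590 ng.h/mL.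

Compound 4 `CC1=C(c2ccccc2)C(c2ccc(OC[C@H](C)N3CC[C@@H](C)C3)cc2)Oc2ccc(O)cc21` carries hydrogen in place of fluoro on an aromatic carbon, a 4-fluorophenyl to phenyl change: hydrogen in place of fluoro on an aromatic carbon. Among the compounds with values here, no measured pair isolates this change. Within the data shown here, the nearest evidence is the single measured step, a 3.4-fold higher number from compound 2 to compound 3 (0.53 log units; beyond the scatter), which is modest and beyond the scatter. That step exchanged 3-hydroxyphenyl for 4-fluorophenyl, so it bears on the same group only indirectly and sets a rough scale, not a direction. A small fall is tentatively expected, with no firm case for a shift beyond the scatter. The expected step is a 1.4-fold lower number from compound 3 to compound 4 (0.15 log units; within the scatter). Compound 4 is estimated at 1400 ng.h/mL, with an expected range of 550 ng.h/mL to 3300 ng.h/mL.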

Compound 4, area under the concentration-time curve: 1000 ng.h/mL
Estimate against measurement, compound 4: 1.4-fold (0.15 log units) above; low and high end bracket the measured number.
By their numbers in this assay, from the lowest: compounds 2, 4 and 3 (each within the scatter of the next, the first and the last beyond it).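

In this assay, the change from 4-fluorophenyl to phenyl gives a 2.0-fold lower number from compound 3 to compound 4 (0.30 log units; within the scatter), the first read on fluoro alone on this aromatic carbon, and the step stays within the scatter. Hydrogen in place of hydroxy gives a 1.7-fold higher number from compound 2 to compound 4 (0.23 log units; within the scatter), also within the scatter, so compound 4 lies within the scatter of both other compounds with numbers, even though those two stand apart beyond it, and neither single change to hydrogen carries a shift beyond the scatter. The data shown offer no explanation for either step.

From the compounds shown here alone, how this position responds to a chloro, a methoxy or an amine remains open, as the comparison of this carbon rests only on fluoro and hydrogen. Whether hydroxy on the para carbon would match the 3-hydroxyphenyl of compound 2 also stays unresolved.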